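The source may report more compounds than this note shows. Statements on the series, on what has been measured and on what is new or still open speak of the compounds shown alone.

Measured in a functional assay on U-87MG ATCC cells for antiproliferative activity against U-87 MG (Homo sapiens), read by MTT assay, with a stated time of 48 h; on this read-out higher numbers stand for weaker inhibition and lower numbers for stronger inhibition:
compound 1 `Cc1nc(-c2ccc(Cl)cc2)sc1C(=O)CSc1nc(-c2cccc(Cl)c2)c(C#N)c(=O)[nH]1`: 40100 nM
compound 2 `Cc1nc(-c2ccc(Cl)cc2)sc1C(=O)CSc1nc(-c2ccc(Cl)cc2)c(C#N)c(=O)[nH]1`: 53000 nM

For the measured compounds named here, compound 1 has only one neighbour on these numbers, and the two cannot be told apart: a 1.3-fold higher number from compound 1 to compound 2 (0.12 log units; within the scatter). Going by the values given here, that step swaps 3-chlorophenyl for 4-chlorophenyl, and it is the only measured step so far.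

Compound 3 `COc1ccc(-c2nc(C)c(C(=O)CSc3nc(-c4cccc(Cl)c4)c(C#N)c(=O)[nH]3)s2)cc1` comes from compound 1 by a different change: methoxy in place of chloro on an aromatic carbon. Here methoxy takes the place of chloro on an aromatic carbon, so 4-chlorophenyl becomes 4-methoxyphenyl. Among the compounds with values here, no measured pair makes this exchange, so the evidence for it is indirect and thin. The natural starting point is compound 1 at 40100 nM. With only a 1.3-fold higher number from compound 1 to compound 2 (0.12 log units; within the scatter) to go on, no shift beyond the scatter is expected in this assay, in either direction. The estimated step is therefore small: a 1.0-fold lower number from compound 1 to compound 3 (0.00 log units; within the scatter). Compound 3 is expected at about 40000 nM, with an estimated range of 14000 nM to 100000 nM.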

Compound 3, half-maximal inhibitory concentration: 78900 nM
Compound 3: the middle estimate sits 2.0-fold (0.30 log units) below what was measured; the range from low to high includes it.
By their numbers in this assay, from the lowest: compounds 1, 2 and 3 (each within the scatter of the next).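

For the compounds shown here, until now, the only measured change concerned the 3-chlorophenyl group, so the 4-chlorophenyl group that compound 1 and compound 3 do not share is a new place to read, on an aromatic carbon para to a large group. In this assay, methoxy in place of chloro, an exchange that brings in a hydrogen-bond acceptor where chloro has none, gives a 2.0-fold higher number from compound 1 to compound 3 (0.29 log units; within the scatter) and so, on this single pair, the two groups cannot be told apart, although the step sits at the edge of what repeated measurements would scatter by. No measurement of any property of these groups is available to bear on this result.

The compounds shown leave open whether a different group at this same place, such as an amine, a carboxylic acid or a longer chain like butoxy, would move the number beyond the scatter, or whether this place tolerates change in general. They also leave open whether methoxy in place of chloro would read the same way with the 4-chlorophenyl group of compound 2 elsewhere on the shared core.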